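Shortening one side chain of compound 1

The source may hold more compounds than are shown below. What is called first, only, known or untested is meant among the compounds shown, and "the series" means these compounds.

Compound 1 `COCCC1=C(N2CC2)C(=O)C(CCOC)=C(N2CC2)C1=O` gives 5.18 in a functional assay on L1210 cells (Mus musculus), with a stated time of 1 days; on this read-out lower numbers stand for lower potency and higher numbers for higher potency (the scale is a negative logarithm). Among the three measured compounds its number is the second highest: compound 2 `CCCC1=C(N2CC2)C(=O)C(CCOC(N)=O)=C(N2CC2)C1=O` gives 4.9, a value within the scatter of compound 1, while compound 3 `CCOC(COC(N)=O)C1=C(N2CC2)C(=O)C(C)=C(N2CC2)C1=O` gives 5.53, which lies beyond the scatter above it. Compound 4 `COCCC1=C(N2CC2)C(=O)C(C)=C(N2CC2)C1=O` is not yet measured. It differs from compound 1 in one place: hydrogen in place of methoxymethyl on a saturated chain carbon bound to a double-bonded ring carbon. Within the data shown here, no measured pair shows this change, so its effect is uncertain; compound 3 also carries a methyl on the shared core and gives 5.53, but it differs elsewhere too. The step of a number 0.02 log units higher from compound 1 to compound 4 (within the scatter) is expected to stay within the usual scatter. Compound 4 is estimated at 5.2, with a range from 4.7 to 5.7.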

Compound 4, logarithm of the reciprocal of the active concentration, log(1/C): 5.19
Compound 4: middle estimate off by 0.01 log units, on the high side, and the stated range covers the measured number.
By their numbers in this assay, from the lowest: compounds 2, 1 and 4 (each within the scatter of the next); then compound 3.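

Replacing 2-methoxyethyl with methyl gives a number 0.01 log units higher from compound 1 to compound 4 (within the scatter) in this assay. At this place on the shared core, the read-out therefore does not separate the longer side chain from the methyl, although methoxymethyl and its hydrogen-bond acceptor are gone. Nothing measured here offers an explanation for this result. Still open, as far as these compounds go, is whether a side chain carrying an amine or a carboxylic acid, or a much longer chain, would leave the number equally unchanged. Whether hydrogen alone, with no methyl left, would do the same also stays unanswered.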